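This account rests on a few compounds, and the source may have more. Where it says the series, first, only, none or still open, it means among the compounds named here.

Measured compounds: compound 1 `CC1=CC[C@H](C(C)(C)NC(=S)N/N=C/c2ccccc2)CC1` with 20600 nM in a functional assay on OVCAR-3 cells (Homo sapiens) for inhibition, read by sulforhodamine B assay, with a stated time of 48 h; on this read-out higher numbers stand for weaker inhibition of growth and lower numbers for stronger inhibition of growth; compound 2 `CC1=CC[C@H](C(C)(C)NC(=S)N/N=C/c2ccccc2O)CC1` with 11800 nM in this assay; compound 3 `CC1=CC[C@H](C(C)(C)NC(=S)N/N=C/c2ccccc2Cl)CC1` with 83600 nM in this assay.

Compound 3 gives the highest number of the three in this assay, set apart from both others by steps beyond the scatter. Compound 4 `CC1=CC[C@H](C(C)(C)NC(=S)N/N=C/c2ccccc2[N+](=O)[O-])CC1` differs from it by nitro in place of chloro on an aromatic carbon. For the measured compounds named here, no measured step exchanges chloro for nitro. The two steps that bear on it both end at compound 3: a 4.1-fold higher number from compound 1 to compound 3 (0.61 log units; beyond the scatter) and a 7.1-fold higher number from compound 2 to compound 3 (0.85 log units; beyond the scatter). Both show the chloro compound weaker than the hydrogen and hydroxy compounds, but they say nothing about nitro. The direction of a 2.1-fold lower number from compound 3 to compound 4 (0.32 log units; beyond the scatter) is therefore expected only tentatively, with wide uncertainty. Compound 4 is estimated at 40000 nM, likely between 10000 nM and 160000 nM.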

Compound 4, concentration for total growth inhibition: 25800 nM
Beside the measured number, compound 4's estimate is 1.6-fold (0.19 log units) above it; the measured number falls inside the stated range.
By their numbers in this assay, from the lowest: compounds 2, 1 and 4 (each within the scatter of the next, the first and the last beyond it); then compound 3.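

In this assay, the loss seen with chloro at this position does not carry over to nitro (a 3.2-fold lower number from compound 3 to compound 4 (0.51 log units; beyond the scatter)), and nitro stands level with hydrogen (a 1.3-fold higher number from compound 1 to compound 4 (0.10 log units; within the scatter)). Hydroxy still gives the lower number of the pair with nitro (a 2.2-fold higher number from compound 2 to compound 4 (0.34 log units; beyond the scatter)), so the groups tried here do not all behave alike at this place. Nothing available here explains why chloro stands apart.

From the compounds shown here alone, whether an amine or a carboxylic acid at this position would fall with hydroxy, nitro or chloro stays open. So does whether a methoxy group would keep the number of compound 2.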